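Three analogues at the limit, and a fourth to come

The compounds below may be only part of what the source reports. "The series", "measured", "known", "first", "only" and "open" are said of these compounds alone.

Compound 1 `Fc1ccc2nc(-c3ccccc3)nc(Nc3ccccc3)c2c1`, compound 2 `Fc1cccc(-c2nc(Nc3ccccc3F)c3cc(F)ccc3n2)c1` and compound 3 `Fc1cccc(-c2nc(Nc3ccc(Br)cc3)c3cc(F)ccc3n2)c1` share one core and differ only in the group on a nitrogen on an aromatic ring. In a functional assay on COLO 205 cells (Homo sapiens) for cytotoxicity, read by MTT assay, with a stated time of 48 h (a lower number here means a stronger inhibitor, a higher number a weaker inhibitor), compound 1 reaches only the limit of the assay, > 50000 nM. In this assay compound 2 likewise gives only a limit, > 50000 nM. In this assay compound 3 also stands at a limit, > 50000 nM. Within the data shown here, the single one-point step among them, a step that the two limits leave unreadable from compound 2 to compound 3, cannot be sized because of the limit of > 50000 nM in this assay, at which 3 of the 3 values shown sit. Compound 3 therefore has no number of its own, and the two other values shown are limits as well.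

Compound 4 `Cc1cccc(Nc2nc(-c3cccc(F)c3)nc3ccc(F)cc23)c1` differs from compound 3 by 3-methylphenyl in place of 4-bromophenyl on a nitrogen on an aromatic ring. Among the measured compounds shown here, no measured step bears readably on this change, and all three values shown sit at the limit; nothing among them points toward a stronger inhibitor. The expected step of a number no higher from compound 3 to compound 4 (the limit leaves the size open) is accordingly none beyond the scatter. Compound 4 is expected to give about 50000 nM in this assay, estimated between 20000 nM and 150000 nM, and most probably again reported only as a limit.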

Compound 4, half-maximal inhibitory concentration: > 50000 nM
Compound 4: no number, only a limit (the forecaster's own chance of this, stated with the estimate: 80%); the middle value sits exactly at the limit.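

Compound 2, compound 3 and compound 4 all stand only at a limit in this assay, so no new step can be read among them: the limit of > 50000 nM in this assay, at which 4 of the 4 values shown sit.

The compounds shown leave open whether any group on this nitrogen would give a readable number, and how far these groups truly differ.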